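The compounds below may be only part of what the source reports. "The series", "measured", "known", "first", "only" and "open" are said of these compounds alone.

Compound 2 `CCN(CC)c1cc2[nH]c(C3CCCCC3)nc2cc1NC(=O)OCC(F)(F)F` carries a diethylamino group on the shared core, a cyclohexyl ring and a carbamate built from 2,2,2-trifluoroethoxy. In an ADME assay on Vero cells (Chlorocebus sabaeus) for cytotoxicity, read by resazurin assay, with a stated time of 3 days (on this read-out higher numbers stand for weaker inhibition and lower numbers for stronger inhibition), compound 2 reaches only the limit of the measurement, > 100 ug/mL. Its closest relative, compound 1 `O=C(Nc1cc2nc(C3CCCCC3)[nH]c2cc1N1CCCC1)OCC(F)(F)F`, differs by pyrrolidin-1-yl in place of diethylamino on an aromatic carbon. In this assay compound 1 also gives only a limit, > 100 ug/mL. The step that the two limits leave unreadable from compound 1 to compound 2 is accordingly unreadable. Compound 3 `CCCCOC(=O)Nc1cc2nc(C3CCCCC3)[nH]c2cc1N(C)CCN(C)C` likewise stands at a limit, > 100 ug/mL. Indeed (the limit of > 100 ug/mL in this assay, at which 3 of the 3 values shown sit).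

Compound 4 `CCN(CC)c1cc2[nH]c(C3CCCCC3)nc2cc1NC(=O)c1ccc(F)cc1` changes the carbamate: 4-fluorophenyl in place of 2,2,2-trifluoroethoxy on a carbonyl carbon. For the measured compounds named here, every value gathered is a limit, and no measured step bears on this change. The size of the step expected in this assay cannot be read from these data, and no direction can be given. The estimate for compound 4 is 100 ug/mL, with a range from 40 ug/mL to 300 ug/mL, and it is most likely to be reported once more as a limit. The expected step is a number no higher from compound 2 to compound 4 (the limit leaves the size open).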

Compound 4, half-maximal inhibitory concentration: > 100 ug/mL
Compound 4: only a limit was reported; the forecaster's own chance of this, stated with the estimate: 75%; the middle value lies on the limit itself.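

No step can be read from compound 2 to compound 4, because both give only a limit in this assay, not a number: the limit of > 100 ug/mL in this assay, at which 4 of the 4 values shown sit. The compounds shown leave open whether 4-fluorophenyl in place of 2,2,2-trifluoroethoxy on a carbonyl carbon changes this read-out at all.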